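Removing a Dimethylamino Group from a Compound at the Limit

This account rests on a few compounds, and the source may have more. Where it says the series, first, only, none or still open, it means among the compounds named here.

Compound 1 `COc1ccc2c(c1)C/C(=C\c1ccc(O)c(O)c1)C2=O` gives 3280 nM in an assay on membranes from brain for displacement of a labelled ligand from adenosine receptor A1 (Rattus norvegicus), read by radioligand binding; on this read-out lower numbers stand for stronger inhibition and higher numbers for weaker inhibition.
Compound 2 `Oc1cccc(C2=CC(O)c3c(O)cccc3O2)c1` gives 956 nM in this assay.
Compound 3 `COc1cccc2c1C/C(=C\c1ccc(N(C)C)cc1)C2=O` gives > 100000 nM in this assay, which is a limit of the assay and not a number.

Compound 3 therefore stands apart from the other two compounds. It sits at the limit of > 100000 nM in this assay, at which 1 of the 3 values shown sits, so only a boundary is known for it, and its true value could lie anywhere beyond that boundary. Compound 1 shares the core of compound 3 and reaches a measured number, and compound 2, built on a different core, reaches a somewhat lower number; the two numbers themselves are all that can be said of that pair.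

Compound 4 `COc1cccc2c1C/C(=C\c1ccccc1)C2=O` has not been measured. It differs from compound 3 in one place: hydrogen in place of dimethylamino on an aromatic carbon, para to a large group. Among the compounds with values here, no measured step of this kind exists in the set, so the size of the step can only be guessed. Because compound 1, which shares the core, gives 3280 nM, a measurable value for compound 4 seems possible, and the step from compound 3 is expected to run toward stronger inhibition, an at least 2.5-fold lower number from compound 3 to compound 4 (0.39 log units; beyond the scatter), though it may not exceed the usual scatter. Compound 4 is estimated at 40000 nM, within 6000 nM to 200000 nM.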

Compound 4, inhibition constant: 1650 nM
The estimate for compound 4 lay 24-fold (1.38 log units) above the measured number; the whole stated range lies above it.
By their numbers in this assay, from the lowest: compounds 2, 4 and 1 (each within the scatter of the next, the first and the last beyond it). At a limit, above all of these: compound 3.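

In this assay, within the data shown here, putting hydrogen in place of dimethylamino on this aromatic carbon, para to a large group, gives an at least 60-fold lower number from compound 3 to compound 4 (1.78 log units; beyond the scatter), the first step in the set that can be read. It shows that on this core, a single change at this one place is enough to turn a compound with no measured number into one with a measured number. The printed size of the step is only a minimum and the true step could be larger, since compound 3 stands at a limit of the assay: the limit of > 100000 nM in this assay, at which 1 of the 4 values shown sits.

On these data alone, only hydrogen and dimethylamino are seen at this carbon, so it stays open whether dimethylamino is a special case or whether other groups there, such as a plain amino group, a methyl or a chlorine, would give a similar result. It is also unknown whether the same change would have a step of similar size on a compound carrying the methoxy group elsewhere on the core, or on a compound with hydroxyl groups on the other aromatic ring.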